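The source may hold more compounds than are shown below. What is called first, only, known or untested is meant among the compounds shown, and "the series" means these compounds.

Measured compounds in an ADME assay on MT4 cells (Homo sapiens) for cytotoxicity, read by MTT assay, with a stated time of 5 days; on this read-out lower numbers stand for higher toxicity in this test and higher numbers for lower toxicity in this test:

compound 1 `Cc1cc(C#N)cc(C)c1Oc1nc(Nc2ccc(C#N)cc2)ncc1-c1ccoc1` gives 4980 nM
compound 2 `Cc1cc(C#N)cc(C)c1Oc1nc(Nc2ccc(C#N)cc2)ncc1-c1cccnc1` gives 13500 nM
compound 3 `Cc1cc(C#N)cc(C)c1Oc1nc(Nc2ccc(C#N)cc2)ncc1-c1ccc(F)cc1` gives 42700 nM

Compound 3 stands highest of the three in this assay; compound 2 is nearest with a 3.2-fold higher number from compound 2 to compound 3 (0.50 log units; beyond the scatter), and compound 1 furthest with an 8.6-fold higher number from compound 1 to compound 3 (0.93 log units; beyond the scatter). Compound 4 `Cc1cc(C#N)cc(C)c1Oc1nc(Nc2ccc(C#N)cc2)ncc1-c1ccncc1` differs from compound 3 by pyridin-4-yl in place of 4-fluorophenyl on an aromatic carbon.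

Within the data shown here, the step that bears most directly on this change is the one between compound 2 and compound 3, a 3.2-fold higher number from compound 2 to compound 3 (0.50 log units; beyond the scatter), where a pyridin-3-yl was replaced by the 4-fluorophenyl. Compound 4 carries a pyridin-4-yl, so the move from compound 3 to compound 4 runs the other way, from the 4-fluorophenyl back to a six-membered ring with one hetero atom. The step of a 2.7-fold higher number from compound 1 to compound 2 (0.43 log units; beyond the scatter) also shows the three measured groups are spread well beyond the scatter. The expectation for compound 4 is therefore a lower number than compound 3, of modest size, a 2.8-fold lower number from compound 3 to compound 4 (0.45 log units; beyond the scatter), bringing it near compound 2. The estimate for compound 4 in this assay is 15000 nM, with a range from 6000 nM to 40000 nM.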

Compound 4, half-maximal cytotoxic concentration: 28000 nM
For compound 4 the middle estimate is 1.9-fold (0.27 log units) below the measured one; low and high end bracket the measured number.
By their numbers in this assay, from the lowest: compound 1; then compound 2; then compounds 4 and 3 (each within the scatter of the next).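

In this assay pyridin-4-yl and pyridin-3-yl are not interchangeable at this position, with a 2.1-fold higher number from compound 2 to compound 4 (0.32 log units; beyond the scatter), so the place of the ring nitrogen counts here and not only its presence. Exchanging the 4-fluorophenyl for pyridin-4-yl gives a 1.5-fold lower number from compound 3 to compound 4 (0.18 log units; within the scatter), so these two six-membered aromatic rings are not separated by this read-out, although one carries a ring nitrogen and the other a fluorine. The furan-3-yl of compound 1 stays apart from this new member as well, with a 5.6-fold higher number from compound 1 to compound 4 (0.75 log units; beyond the scatter).

No available data account for these differences. On these data alone, how the series behaves with a non-aromatic group on this carbon, such as a morpholine or a carboxylic acid, remains open.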